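Chloro for Fluoro on a Shared Core

The source may report more compounds than this note shows. Statements on the series, on what has been measured and on what is new or still open speak of the compounds shown alone.

Of the compounds shown here, three sharing one core have been tested in an assay on isolated protein for displacement of a labelled ligand from metabotropic glutamate receptor 5 (Homo sapiens), with a stated time of 60 min, tested at 1 uM; on this read-out higher numbers stand for more inhibition at the one concentration tested (going by the name of the read-out) and lower numbers for less inhibition. Compound 1 `CC1CCN(c2c(S(=O)(=O)c3ccccc3)cnc3cc(Cl)ccc23)CC1` gives 93%. Compound 2 `CC1CCN(c2c(S(=O)(=O)c3cc(Cl)cc(Cl)c3)cnc3cc(Cl)ccc23)CC1`, which carries 3,5-dichlorophenyl in place of phenyl on a sulfonyl sulfur, gives 93%; the step of no change at the digits printed from compound 1 to compound 2 (within the scatter) shows that this replacement did not shift the read-out beyond the scatter. Compound 3 `COc1ccc(S(=O)(=O)c2cnc3cc(F)ccc3c2N2CCC(C)CC2)cc1` gives 90%. Its figure is not separated from those of compound 1 or compound 2 beyond the scatter, so the three measured compounds stand together at a high level of inhibition.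

Compound 4 `COc1ccc(S(=O)(=O)c2cnc3cc(Cl)ccc3c2N2CCC(C)CC2)cc1` has not yet been measured. It differs from compound 3 in one place: chloro in place of fluoro on an aromatic carbon. Within the data shown here, no measured step tests this exact exchange. Among the measured compounds shown here, the only step available, from compound 1 to compound 2, concerns chlorines entering on a different ring and was flat within the scatter, and all three measured compounds give similarly high numbers despite differing in several places. On that basis no step beyond the scatter is expected in this assay.

Compound 4 is therefore expected to give about 90%, with a range from 80% to 97%. The expected step of no change at the digits printed from compound 3 to compound 4 (within the scatter) is estimated to lie within the usual scatter.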

Compound 4, a percentage reported as inhibition, at one concentration (the size of the read-out at that concentration, not a potency): 79%
Compound 4: middle estimate off by 11 percentage points, on the high side; the whole stated range lies above it.
By their numbers in this assay, from the lowest: compound 4; then compounds 3, 1 and 2 (each within the scatter of the next).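

In this assay, among these compounds, chloro in place of fluoro on this aromatic carbon of the shared core is the first single change here to move the number beyond the scatter, with a number 11 percentage points lower from compound 3 to compound 4 (beyond the scatter). Chloro at this position does not lower the number on its own, since compound 1 and compound 2 carry it too; with chloro kept in place, 4-methoxyphenyl in place of 3,5-dichlorophenyl on the sulfonyl sulfur gives a number 14 percentage points lower from compound 2 to compound 4 (beyond the scatter), and methoxy in place of hydrogen on an aromatic carbon gives a number 14 percentage points lower from compound 1 to compound 4 (beyond the scatter), so among these four compounds the lower number appears only where chloro and 4-methoxyphenyl occur together. Nothing available here explains why this combination stands apart.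

Still open, on these data alone, is whether bromo or a nitrile on the same aromatic carbon would give a number closer to that of compound 3 or to that of compound 4. Also open, as far as these compounds go, is how fluoro on the core would behave with plain phenyl or 3,5-dichlorophenyl on the sulfonyl sulfur, which would show whether the fluoro-to-chloro step depends on that group.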